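Amino-acid substituents on the quinone of compound 1

The source may hold more compounds than are shown below. What is called first, only, known or untested is meant among the compounds shown, and "the series" means these compounds.

For the measured compounds named here, compound 1 `CC1=CCC[C@H]2[C@](C)(CC3=CC(=O)C=C(NCCC(=O)O)C3=O)[C@@H](C)CC[C@]12C` and compound 2 `CC(C)(C)C1=CC(=O)C=C(NCC(=O)O)C1=O` are the two measured members of this set, both carrying an amino-acid substituent on a quinone. In a functional assay on Fem-X cells (Homo sapiens) for cytotoxicity, read by MTT assay, with a stated time of 72 h (on this read-out higher numbers stand for weaker inhibition and lower numbers for stronger inhibition), compound 1 gives 20200 nM. In this assay compound 2 gives 34300 nM. Going by the values given here, the two numbers lie within the usual scatter of each other, so neither compound stands apart from the other on this read-out, and no step between measured compounds is available to anchor the next change.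

Compound 3 `CSCC[C@H](NC1=CC(=O)C=C(C[C@]2(C)[C@@H](C)CC[C@]3(C)C(C)=CCC[C@@H]23)C1=O)C(=O)O` keeps the core of compound 1 and differs from it in one place: 1-carboxy-3-(methylsulfanyl)propyl in place of 2-carboxyethyl on an amine nitrogen. Among the compounds with values here, as no measured pair shows the effect of such a change on the amine nitrogen, the expectation rests on the weak inhibition of compound 1 alone.

The step from compound 1 to compound 3 is expected to be small, a 1.3-fold lower number from compound 1 to compound 3 (0.10 log units; within the scatter), with no direction established beyond the scatter. Compound 3 is therefore estimated at 16000 nM, with a range from 6000 nM to 40000 nM.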

Compound 3, half-maximal inhibitory concentration: 19400 nM
Beside the measured number, compound 3's estimate is 1.2-fold (0.08 log units) below it, and the stated range covers the measured number.
By their numbers in this assay, from the lowest: compounds 3, 1 and 2 (each within the scatter of the next).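

For the compounds shown here, replacing 2-carboxyethyl with 1-carboxy-3-(methylsulfanyl)propyl on the amine nitrogen of the shared core gives a 1.0-fold lower number from compound 1 to compound 3 (0.02 log units; within the scatter) in this assay, which is the only step in the set that can be read at this position. The earlier compounds shown here gave no such pair, and this one shows that a substituent with more heavy atoms, a sulfur and a defined stereocentre leaves the number on this read-out within the scatter of the 2-carboxyethyl compound. No supporting data on why the two compounds read alike are available, so the step stands as an observation only.

From the compounds shown here alone, it remains open whether a substituent of another kind on this nitrogen, such as a chain ending in a primary amine, a benzyl-bearing amino-acid side chain or a methyl ester in place of the carboxylic acid, would move the number beyond the scatter. Also open, going by these compounds, are the opposite configuration at the new stereocentre and whether the same exchange on the core of compound 2 would read the same way.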